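A few compounds are considered here, and "the series" means these few. Any claim that something is new, unique, unknown or untested is made for them only; others in the source may bear on it.

Measured in this assay so far:

- Compound 1 `COc1ccc(OC)c(/C=N/c2c(C#N)ncn2-c2ccc(F)cc2)c1` gives 7090 nM
- Compound 2 `N#Cc1ncn(-c2ccc(F)cc2)c1/N=C/c1ccc([N+](=O)[O-])cc1` gives 9100 nM
- Compound 3 `COc1cc(/C=N/c2c(C#N)ncn2-c2ccc(F)cc2)ccc1O` gives 9990 nM

All three numbers come from a functional assay on MCF7 cells (Homo sapiens) for antiproliferative activity, read by MTT assay, with a stated time of 48 h; on this read-out lower numbers stand for stronger inhibition and higher numbers for weaker inhibition. Compound 3 carries the highest of the three numbers, but its separation from compound 2 and from compound 1 lies within the usual scatter of this assay, so no ranking among the three is claimed; the set simply sits in a narrow band.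

Compound 4 `N#Cc1ncn(-c2ccc(F)cc2)c1/N=C/c1ccc(O)cc1` is the next member and is not yet measured. It differs from compound 3 by hydrogen in place of methoxy on an aromatic carbon. Within the data shown here, no measured pair differs in a single place, so no directly comparable step exists to lean on; the three measured values only show that the variations present so far have not moved the read-out beyond the scatter.

The step from compound 3 to compound 4 is therefore expected to be small, a 1.0-fold higher number from compound 3 to compound 4 (0.00 log units; within the scatter), with no direction beyond the scatter claimed. For compound 4 the estimate in this assay is 10000 nM, with a range from 4000 nM to 25000 nM.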

Compound 4, half-maximal inhibitory concentration: 11500 nM
Beside the measured number, compound 4's estimate is 1.2-fold (0.06 log units) below it; the range from low to high includes it.
By their numbers in this assay, from the lowest: compounds 1, 2, 3 and 4 (each within the scatter of the next).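

In this assay hydrogen in place of methoxy on an aromatic carbon, ortho to a hydroxy group, gives a 1.2-fold higher number from compound 3 to compound 4 (0.06 log units; within the scatter), so the methoxy group is not required to keep the read-out in this band. At the same time, hydroxy in place of nitro on an aromatic carbon gives a 1.3-fold higher number from compound 2 to compound 4 (0.10 log units; within the scatter), so nitro and hydroxy cannot be told apart here, and the series now has single-place pairs, neither of which leaves the scatter. No evidence is at hand that explains the size of these steps.

From the compounds shown here alone, whether an amine or a carboxylic acid on this aromatic carbon would move the number beyond the scatter remains open. Also open, going by these compounds, is whether a change to the shared core, rather than to this aromatic ring, would take the series out of the band.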